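The compounds below may be only part of what the source reports. "The series", "measured", "known", "first", "only" and "open" are said of these compounds alone.

Measured in an assay on HEK293 cells for displacement of a labelled ligand from prostaglandin D2 receptor 2 (Homo sapiens); on this read-out lower numbers stand for stronger inhibition and higher numbers for weaker inhibition:
compound 1 `O=C(O)Cn1c(SCCCCOc2ccccc2)nc2ccccc21` gives 1400 nM;
compound 2 `O=C(O)Cn1c(SCCCNc2ccccc2)nc2ccccc21` gives 2690 nM;
compound 3 `CCOC(=O)CCSc1nc2ccccc2n1CC(=O)O` gives 11400 nM.

Compound 1 holds the lowest number of the three; the step of a 1.9-fold higher number from compound 1 to compound 2 (0.28 log units; within the scatter) lies within the scatter, while the gap to compound 3 lies beyond it. Compound 4 `CCOC(=O)CCCSc1nc2ccccc2n1CC(=O)O` differs from compound 1 as follows: ethoxycarbonyl in place of phenoxymethyl on a saturated chain carbon, three bonds along the chain from a sulfur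

The step of a 4.2-fold higher number from compound 2 to compound 3 (0.63 log units; beyond the scatter) bears most directly on this change, since it also brings in ethoxycarbonyl at the chain end, though one bond nearer the sulfur. Compound 4 is expected to sit closer to compound 3 than to compound 1, so in this assay a higher number is expected, a step of roughly a 5.7-fold higher number from compound 1 to compound 4 (0.76 log units; beyond the scatter). For compound 4 the estimate is 8000 nM, with a range from 3000 nM to 20000 nM.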

Compound 4, half-maximal inhibitory concentration: 4410 nM
Compound 4: the middle estimate sits 1.8-fold (0.26 log units) above what was measured; the measured number falls inside the stated range.
By their numbers in this assay, from the lowest: compounds 1, 2 and 4 (each within the scatter of the next, the first and the last beyond it); then compound 3.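

In this assay, ethoxycarbonyl in place of phenoxymethyl on this chain carbon gives a 3.2-fold higher number from compound 1 to compound 4 (0.50 log units; beyond the scatter) and so the loss of the aromatic ring carries only a modest cost. Against anilino, the same group gives a 1.6-fold higher number from compound 2 to compound 4 (0.21 log units; within the scatter) and the two are not separated on this read-out. With ethoxycarbonyl kept, placing it one bond further from the sulfur gives a 2.6-fold lower number from compound 3 to compound 4 (0.41 log units; beyond the scatter) and chain length therefore counts on its own.

Nothing measured here accounts for these shifts. Still open, on these data alone, is whether a carboxylic acid or an amide at the chain end, or a longer chain carrying ethoxycarbonyl, would follow the same trend.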